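Swapping the aryl on the anilino nitrogen of compound 1

A few compounds are considered here, and "the series" means these few. Any claim that something is new, unique, unknown or untested is made for them only; others in the source may bear on it.

Compound 1, `COc1cc(NC(=O)Nc2cc(Nc3ccc(C(C)(C)C)cc3)ncn2)cc(OC)c1`, gives 74.1% in a functional assay on PC-9 cells (Homo sapiens) for inhibition, read by MTT assay, with a stated time of 48 h, tested at 10 uM (on this read-out lower numbers stand for less inhibition and higher numbers for more inhibition at the one concentration tested (going by the name of the read-out)), the lowest of the three numbers recorded. Compound 2, `Cc1ccc(Nc2cc(NC(=O)Nc3c(Cl)cccc3Cl)ncn2)cc1C`, gives 92.1% in this assay, and compound 3, `O=C(Nc1cc(Nc2ccc(F)c(Cl)c2)ncn1)Nc1c(Cl)cccc1Cl`, gives 91.1%; both stand beyond the scatter above compound 1. Compound 4, `COc1cc(NC(=O)Nc2cc(Nc3cc(Br)ccc3OC)ncn2)cc(OC)c1`, has not yet been measured. It differs from compound 1 in one place: 5-bromo-2-methoxyphenyl in place of 4-(tert-butyl)phenyl on a nitrogen on an aromatic ring.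

Within the data shown here, one measured step bears on this kind of change, the replacement of the aryl on a nitrogen on an aromatic ring within a different urea partner: a number 1 percentage points lower from compound 2 to compound 3 (within the scatter). That step left the inhibition unchanged within the scatter. Nothing in the data shows that the aryl on this nitrogen moves the read-out, so no step beyond the scatter is expected for compound 4 in this assay, and its inhibition is estimated as a number 1.9 percentage points higher from compound 1 to compound 4 (within the scatter). Compound 4 is therefore expected to give about 76%, between 58% and 92%.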

Compound 4, a percentage reported as inhibition, at one concentration (the size of the read-out at that concentration, not a potency): 82.5%
Compound 4: the middle estimate sits 6.5 percentage points below what was measured; the measured number falls inside the stated range.
By their numbers in this assay, from the lowest: compounds 1, 4, 3 and 2 (each within the scatter of the next, the first and the last beyond it).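

The change on this nitrogen now has a second reading, this time with the urea partner of compound 1 in place: in this assay it gives a number 8.4 percentage points higher from compound 1 to compound 4 (within the scatter) and so stays inside the scatter. The earlier step, a number 1 percentage points lower from compound 2 to compound 3 (within the scatter), also stayed inside it, so neither pair shows the aryl on this nitrogen moving the read-out, although here a 4-(tert-butyl)phenyl of carbon only gave way to a 5-bromo-2-methoxyphenyl carrying a hydrogen-bond acceptor. No measurement on hand offers an explanation for this result.

The compounds shown leave open whether an amine or a carboxylic acid on this aryl would shift the number beyond the scatter. What the urea partner contributes on its own cannot be read, since compound 1 and compound 2 differ in more than one place.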